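The source may report more compounds than this note shows. Statements on the series, on what has been measured and on what is new or still open speak of the compounds shown alone.

In a functional assay on HT-29 cells (Homo sapiens) (a higher number here means that more compound is needed for the effect, a lower number that less compound is needed), compound 1 (`CN1CCN(C(=O)c2cc(-c3ccccc3)sc2NC(N)=O)CC1`) gives "not determined" (no result reported), so it offers no number for comparison. Compound 2 (`CS(=O)(=O)Nc1ccc(-c2cc(C(=O)N[C@H]3CCCNC3)c(NC(N)=O)s2)cc1`) reads 2200 nM. Among the measured compounds shown here, this is the only number available, and its rank cannot be judged from it.

Compound 3 (`NC(=O)Nc1sc(-c2ccc(N)cc2)cc1C(=O)N[C@H]1CCCNC1`) is still to be measured. It differs from compound 2 by hydrogen in place of methylsulfonyl on a nitrogen on an aromatic ring, which reads as methanesulfonamido to amino.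

For the measured compounds named here, no measured pair shows this change, so the data give no direction for it. The expectation in this assay is therefore no step beyond the scatter, and the estimated step is a 1.2-fold lower number from compound 2 to compound 3 (0.09 log units; within the scatter). That expectation rests only on compound 2 at 2200 nM, which leaves it wide. Compound 3 is expected at 1800 nM, with an estimated range from 450 nM to 7500 nM.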

Compound 3, half-maximal effective concentration: 920 nM
Compound 3: middle estimate off by 2.0-fold (0.29 log units), on the high side, and the stated range covers the measured number.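

In this assay, among the compounds shown here, the change from methanesulfonamido to amino gives the first readable step, a 2.4-fold lower number from compound 2 to compound 3 (0.38 log units; beyond the scatter). This step is modest but lies beyond the usual scatter, so the position on the nitrogen on an aromatic ring does respond to what it carries. The methylsulfonyl is also not needed for a measurable effect here, as the compound with hydrogen in its place still gives a number. Nothing in the data shown bears on the reason for this step.

An acetyl or a methyl on that nitrogen does not appear among the compounds shown, so it stays open whether the step follows from the free amino group or simply from the loss of methylsulfonyl. With a single pair, the size of the step also cannot be tested on another part of the shared core.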